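Iodo for Chloro in a Weakly Antiproliferative Pair

The compounds below may be only part of what the source reports. "The series", "measured", "known", "first", "only" and "open" are said of these compounds alone.

Measured compounds:
compound 1, `NC(=O)c1c(NC(=O)c2ccccc2Cl)sc2c1CCN(C(=S)Nc1ccccc1C(F)(F)F)C2`: 26700 nM
compound 2, `NC(=O)c1c(NC(=O)c2ccccc2Cl)sc2c1CCN(C(=S)Nc1ccc(C(F)(F)F)cc1)C2`: > 50000 nM

Of the compounds shown here, two have been tested in a functional assay on HeLa cells (Homo sapiens) for antiproliferative activity, with a stated time of 24 h; a higher number here means a weaker inhibitor, a lower number a stronger inhibitor. Compound 1, with the structure `NC(=O)c1c(NC(=O)c2ccccc2Cl)sc2c1CCN(C(=S)Nc1ccccc1C(F)(F)F)C2`, gives 26700 nM in this assay, and this is the only numerical result shown. Compound 2, `NC(=O)c1c(NC(=O)c2ccccc2Cl)sc2c1CCN(C(=S)Nc1ccc(C(F)(F)F)cc1)C2`, is reported in this assay only as a limit, > 50000 nM. Among the compounds with values here, the single measured step, an at least 1.8-fold higher number from compound 1 to compound 2 (0.27 log units; that floor lies within the scatter), exchanges 2-(trifluoromethyl)phenyl for 4-(trifluoromethyl)phenyl on an amide-type nitrogen, and its floor lies within the scatter; the value it ends at is the limit described by the limit of > 50000 nM in this assay, at which 1 of the 2 values shown sits.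

Compound 3, `NC(=O)c1c(NC(=O)c2ccccc2I)sc2c1CCN(C(=S)Nc1ccccc1C(F)(F)F)C2`, differs from compound 1 by iodo in place of chloro on an aromatic carbon. Within the data shown here, no measured step touches this halogen, so the one step on record does not bear on the change; it concerns a different part of the shared core. With nothing to point either way, one expects no step beyond the scatter, that is, an expected step of a 1.1-fold lower number from compound 1 to compound 3 (0.03 log units; within the scatter) in this assay. Compound 3 is therefore estimated at 25000 nM in this assay, with a range from 8000 nM to 70000 nM, and a real chance that only a limit is reported.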

Compound 3, half-maximal inhibitory concentration: 49200 nM
Beside the measured number, compound 3's estimate is 2.0-fold (0.29 log units) below it, and the stated range covers the measured number.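

The first change shown at this place, iodo in place of chloro on an aromatic carbon of the 2-chlorophenyl group, gives in this assay a 1.8-fold higher number from compound 1 to compound 3 (0.27 log units; within the scatter). The two halogens therefore cannot be told apart in this read-out, and the position carries iodo without any step beyond the scatter, so the weak antiproliferative level of compound 1 is neither clearly lost nor improved. Compound 3 receives a number, whereas compound 2 remains the only compound reported as a limit, which bounds what can be read from this small set: the limit of > 50000 nM in this assay, at which 1 of the 3 values shown sits.

Only chloro and iodo are shown at this position, so it remains open whether a fluoro, a methoxy, an amine or a carboxylic acid in their place would move the number beyond the scatter, in either direction. Within the data shown here, it also remains open whether iodo would behave in the same way alongside the 4-(trifluoromethyl)phenyl group on the amide-type nitrogen, where the only reading so far is a limit.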